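A few compounds are considered here, and "the series" means these few. Any claim that something is new, unique, unknown or untested is made for them only; others in the source may bear on it.

Measured compounds:
- compound 1 `Cc1ccncc1C(=O)N1CC(Oc2cncc(N3C(=O)c4ccc(Cl)cc4C3(C)C)c2)C1` gives 4 nM
- compound 2 `CC1(C)CN(c2cccnc2)C(=O)c2ccc(Cl)cc21` gives 1540 nM

The study covers two measured compounds and one still to be measured, all read in an assay on cells for inhibition of cytochrome P450 11B2, mitochondrial (Homo sapiens), read by HTRF; on this read-out higher numbers stand for weaker inhibition and lower numbers for stronger inhibition. Compound 1 holds the lowest number of the two. Its nearest neighbour is compound 2, and the two numbers are far apart, well beyond the scatter, so compound 1 is clearly the stronger inhibitor of the pair. Among the compounds with values here, no pair of measured compounds that differ in one place has been put side by side, so no single step has yet been sized.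

The unmeasured compound is compound 3 `Cn1cc(C(=O)N2CC(Oc3cncc(N4C(=O)c5ccc(Cl)cc5C4(C)C)c3)C2)cn1`. It differs from compound 1 by 1-methyl-1H-pyrazol-4-yl in place of 4-methylpyridin-3-yl on a carbonyl carbon. The rest of the shared core is kept unchanged.

Within the data shown here, with no measured step to lean on, the expectation rests only on compound 1. He expects a small step, a 2.0-fold higher number from compound 1 to compound 3 (0.30 log units; within the scatter), towards a somewhat higher number, though one that may well fall within the scatter. Compound 3 is therefore estimated at 8 nM, with a range from 2 nM to 40 nM.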

Compound 3, half-maximal inhibitory concentration in the cytochrome P450 11B2, mitochondrial assay: 0.5 nM
For compound 3 the middle estimate is 16-fold (1.20 log units) above the measured one; the measured number lies below the stated range.
By their numbers in the cytochrome P450 11B2, mitochondrial assay, from the lowest: compound 3; then compound 1; then compound 2.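

Within the data shown here, putting 1-methyl-1H-pyrazol-4-yl in place of 4-methylpyridin-3-yl on the carbonyl carbon gives, in the cytochrome P450 11B2, mitochondrial assay, an 8.0-fold lower number from compound 1 to compound 3 (0.90 log units; beyond the scatter), the first step in this set that can be sized, and it shows that this position still responds to the ring it carries even when the number is already low. In a physicochemical assay for solubility, in phosphate buffer, with a stated time of 2 h, at pH 6.5 (a lower number here means a less soluble compound, a higher number a more soluble compound), the same change gives a 1.1-fold higher number from compound 1 to compound 3 (0.03 log units; within the scatter), with compound 1 at 290 ug/mL and compound 3 at 310 ug/mL, so the two compounds cannot be told apart on this read-out while they do separate on the first. Nothing measured here accounts for the step.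

The compounds shown leave open whether the step follows the five-membered ring as such or the methyl on it; a plain 1H-pyrazol-4-yl or a phenyl on the same carbonyl carbon would begin to separate the two. On these data alone, compound 2 differs from compound 1 in more than one place, so how much the part of compound 1 that compound 2 lacks contributes also stays open.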